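Branching the side chain of an enyne diester

The source may hold more compounds than are shown below. What is called first, only, known or untested is meant among the compounds shown, and "the series" means these compounds.

Measured so far:
- compound 1, `CCC(C#CC(=O)OC)O/C=C/C(=O)OC`: 320 nM
- compound 2, `CCOC(=O)C#CC(C[C@@H](C)CCC=C(C)C)O/C=C/C(=O)OCC`: 2600 nM

Of the compounds shown here, two have been measured in a functional assay on HBL-100 cells (Homo sapiens) for antiproliferative activity, read by sulforhodamine B assay, with a stated time of 48 h; on this read-out lower numbers stand for stronger inhibition of growth and higher numbers for weaker inhibition of growth. Compound 1 gives 320 nM, the lowest of the two numbers. Within the data shown here, compound 2 gives 2600 nM in this assay, a higher number that lies beyond the scatter of the two values; compound 2 differs from compound 1 in more than one place, so no single step is drawn between them.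

Compound 3, `COC(=O)C#CC(O/C=C/C(=O)OC)C(C)C`, is not yet measured. It differs from compound 1 by methyl in place of hydrogen on a saturated chain carbon bound to two saturated chain carbons. Compound 3 keeps the methyl esters of compound 1; only the saturated chain is branched.

Among the measured compounds shown here, with no single-change step between measured compounds, the expectation for compound 3 rests on the value of compound 1 alone. A small change of this kind is expected to move this assay only slightly, if at all, so the step from compound 1 to compound 3 is estimated as a 1.4-fold higher number from compound 1 to compound 3 (0.15 log units; within the scatter), likely within or just beyond the scatter, leaning toward weaker inhibition. Compound 3 is therefore expected to give about 450 nM in this assay, in a range from 150 nM to 1400 nM.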

Compound 3, concentration for 50% growth inhibition: 450 nM
For compound 3 middle estimate and measured number coincide at the digits printed; low and high end bracket the measured number.
By their numbers in this assay, from the lowest: compounds 1 and 3 (each within the scatter of the next); then compound 2.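

In this assay, among these compounds, the first step between compounds that differ in one place reads a 1.4-fold higher number from compound 1 to compound 3 (0.15 log units; within the scatter). Methyl in place of hydrogen on a saturated chain carbon bound to two saturated chain carbons, which can also be read as ethyl to isopropyl, therefore leaves the number within the scatter, so this position takes this small branch without a change that can be told from repeat variation, something compound 2 could not show, as it differs from compound 1 in more than one place. Nothing available here accounts for this result, and the step stands only as an observation.

The compounds shown leave open how the value of compound 2, 2600 nM, relates to its longer branched chain and to its ethyl esters taken one at a time. Also open, from the compounds shown here alone, is whether a tert-butyl group or a phenyl ring at this position, or a carboxylic acid in place of a methyl ester, would stay within the scatter of compound 1 at 320 nM as compound 3 does.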